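The source may report more compounds than this note shows. Statements on the series, on what has been measured and on what is new or still open speak of the compounds shown alone.

Compound 3 `O=C(NCc1ccncc1)Nc1ccc(S(=O)(=O)NCc2ccccc2)cc1` sits at the top of the three numbers measured in an assay on isolated protein for activation of Nicotinamide phosphoribosyltransferase (Homo sapiens) (a lower number here means that less compound is needed, a higher number that more compound is needed for the effect), where compound 3 gives 102 nM. Compound 2 `O=C(NCc1ccncc1)Nc1ccc(S(=O)(=O)c2ccccc2Cl)cc1` gives 79 nM, and the step of a 1.3-fold higher number from compound 2 to compound 3 (0.11 log units; within the scatter) is within the scatter, so the two cannot be ranked. Compound 1 `CN(Cc1ccccc1)S(=O)(=O)c1ccc(NC(=O)NCc2ccncc2)cc1` gives 23 nM, and the step of a 4.4-fold higher number from compound 1 to compound 3 (0.65 log units; beyond the scatter) is beyond the scatter. Compound 4 `O=C(NCc1ccncc1)Nc1ccc(S(=O)(=O)c2ccccc2)cc1` differs from compound 3 by phenyl in place of benzylamino on a sulfonyl sulfur. The measured step that bears on this is a 1.3-fold higher number from compound 2 to compound 3 (0.11 log units; within the scatter), which exchanged a closely related group on the same sulfonyl sulfur and stayed within the scatter. A step of comparable size is therefore expected in this assay, a 1.4-fold lower number from compound 3 to compound 4 (0.13 log units; within the scatter), with no clear direction. Compound 4 is estimated at 75 nM, in a range from 25 nM to 220 nM.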

Compound 4, half-maximal effective concentration: 85 nM
Compound 4: the middle estimate sits 1.1-fold (0.05 log units) below what was measured, within the range that was stated.
By their numbers in this assay, from the lowest: compound 1; then compounds 2, 4 and 3 (each within the scatter of the next).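

Phenyl and benzylamino on the sulfonyl sulfur cannot be told apart, with a 1.2-fold lower number from compound 3 to compound 4 (0.08 log units; within the scatter). A hydrogen or a chloro on the aromatic carbon also cannot be told apart in this assay, with a 1.1-fold higher number from compound 2 to compound 4 (0.03 log units; within the scatter). Only benzyl(methyl)amino stands apart from phenyl, with a 3.7-fold higher number from compound 1 to compound 4 (0.57 log units; beyond the scatter), and no measurement here accounts for any of these steps.

Going by these compounds, it remains open whether an ethyl group on the sulfonamide nitrogen would give a number like that of compound 1 at 23 nM. On these data alone, the effect of a methoxy group or a carboxylic acid on the phenyl ring of compound 4 also remains open.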